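A few compounds are considered here, and "the series" means these few. Any claim that something is new, unique, unknown or untested is made for them only; others in the source may bear on it.

Measured in an ADME assay on a cell-free system (plasma, Homo sapiens) for protein binding:
- compound 1 `CCc1cc2oc(=O)n(CCC(=O)O)c2cc1Cl`: 98.7%
- compound 2 `C[C@@H](Oc1cc2oc(=O)n(CCC(=O)O)c2cc1Cl)c1cccnn1`: 68.1%

Of these two, compound 2 is the less bound and so leaves the larger free share, and its gap to compound 1 lies beyond the usual scatter of repeated measurements. Two compounds do not make a trend. They also differ in more than one place, so the gap cannot be pinned on any single group.

Compound 3 `O=C(O)CCn1c(=O)oc2cc(OCC3CC3)c(Cl)cc21` has not yet been measured. It keeps the core of compound 2 and changes one group on an oxygen on an aromatic ring: a group of 4 heavy atoms (4 carbon; one three-membered non-aromatic ring of carbon only) in place of a group of 8 heavy atoms (6 carbon, 2 nitrogen; one six-membered aromatic ring with 2 hetero atoms), on an oxygen on an aromatic ring. The six-membered aromatic ring with 2 hetero atoms is gone and cyclopropylmethyl stands in its place.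

Compound 1, which also lacks that ring, shows 98.7% in this assay, so the expectation leans towards it. Going by the values given here, this one comparison is the only guide available. A large rise in binding, beyond the scatter, is expected, with an estimated an 8.0-fold lower unbound fraction from compound 2 to compound 3 (0.90 log units; beyond the scatter). For compound 3 the estimated value is 96%, with an expected range from 89% to 99%.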

Compound 3, plasma protein binding: 96%
For compound 3 middle estimate and measured number coincide at the digits printed, and the stated range covers the measured number.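

In this assay, the shared core now has a one-place comparison on an oxygen on an aromatic ring: cyclopropylmethyl in place of the group carrying the six-membered aromatic ring with 2 hetero atoms gives an 8.0-fold lower unbound fraction from compound 2 to compound 3 (0.90 log units; beyond the scatter) and so ties a large change in binding to this position. A second one-place comparison, cyclopropylmethoxy in place of ethyl on an aromatic carbon, gives a 3.1-fold higher unbound fraction from compound 1 to compound 3 (0.49 log units; beyond the scatter), which places compound 3 between the other two compounds, with both steps beyond the scatter. No measurement here bears on why these steps have the size they do.

On these data alone, the change from compound 2 to compound 3 removes the ring, its two nitrogens and the defined stereocentre together, so the share of each in the step remains unknown. As far as these compounds go, a benzyl group on the same oxygen, whose ring holds only carbon, or a chain ending in an amine, would test this further, and the carboxylic acid chain stays the same throughout, so its part in the binding also remains open.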